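This account rests on a few compounds, and the source may have more. Where it says the series, first, only, none or still open, it means among the compounds named here.

Measured so far:
Compound 1 `CC1(C)CCN(S(=O)(=O)c2ccc(NC(=O)c3ccc([N+](=O)[O-])o3)cc2)CC1` – in an ADME assay on IMR-90 cells (Homo sapiens) for cytotoxicity, read by CellTiter-Blue, with a stated time of 46 h (a lower number here means that less compound is needed, a higher number that more compound is needed for the effect), compound 1 reaches only the assay limit > 25000 nM.
Compound 2 `O=C(Nc1ccc(S(=O)(=O)N2CCOCC2)cc1)c1ccccc1` – in this assay compound 2 reaches only the assay limit > 25000 nM.

Compound 2 therefore stands at a limit rather than at a number; both values shown sit at the limit of > 25000 nM in this assay, at which 2 of the 2 values shown sit, so nothing separates compound 1 from compound 2 in this assay. Compound 3 `Cc1ccc(C(=O)Nc2ccc(S(=O)(=O)N3CCOCC3)cc2)o1` differs from compound 2 in one place: 5-methylfuran-2-yl in place of phenyl on a carbonyl carbon. For the measured compounds named here, no measured pair differs by exactly this change, so no measured step guides the expectation. With both known values at the limit, no shift beyond the usual scatter is foreseen, and the most likely outcome is that compound 3 again reaches only the limit in this assay. The step from compound 2 to compound 3 is expected to be a step that the limit leaves unreadable from compound 2 to compound 3. For compound 3 the estimate is 30000 nM, with a range from 10000 nM to 100000 nM.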

Compound 3, half-maximal effective concentration: > 25000 nM
Compound 3: only a limit was reported; the forecaster's own chance of this, stated with the estimate: 80%; the middle value does not contradict the limit.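

Compound 2 and compound 3 both give only a limit in this assay, so no step can be read for 5-methylfuran-2-yl in place of phenyl on a carbonyl carbon. The compounds shown leave open what concentration, if any, would reach the effect in any of them, as all sit at one limit: the limit of > 25000 nM in this assay, at which 3 of the 3 values shown sit.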